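Swapping Ethynyl for Furan-3-yl on Two Related Nucleosides

The source may hold more compounds than are shown below. What is called first, only, known or untested is meant among the compounds shown, and "the series" means these compounds.

Compound 1, with the structure `C#Cc1cn([C@@H]2O[C@H](CO)[C@@H](O)[C@H]2O)c2ncnc(C)c12`, is the anchor of this small set. In a functional assay on CEM-DNR-bulk cells (Homo sapiens), read by MTT assay, with a stated time of 72 h (a higher number here means a weaker inhibitor, a lower number a stronger inhibitor), compound 1 gives 160 nM. Compound 2, `Cc1ncnc2c1c(-c1ccoc1)cn2[C@@H]1O[C@H](CO)[C@@H](O)[C@H]1O`, carries the change (furan-3-yl in place of ethynyl on an aromatic carbon), and the step of an at least 120-fold higher number from compound 1 to compound 2 (2.09 log units; beyond the scatter) shows how sharply the inhibition falls away. The value of compound 2 in this assay is a limit of the measurement, > 20000 nM, not a number.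

Compound 3, `C#Cc1cn([C@@H]2O[C@H](CO)[C@@H](O)[C@H]2O)c2nc(N)nc(OC)c12`, has a different core; the difference between its core and that of compound 1 is not broken down here. In this assay compound 3 also reaches only a limit, > 20000 nM.

Compound 4, `COc1nc(N)nc2c1c(-c1ccoc1)cn2[C@@H]1O[C@H](CO)[C@@H](O)[C@H]1O`, has not yet been measured. It arises from compound 3 by the same change, (furan-3-yl in place of ethynyl on an aromatic carbon), at the same place as before. Because the earlier step of an at least 120-fold higher number from compound 1 to compound 2 (2.09 log units; beyond the scatter) was large and because the limit of > 20000 nM in this assay, at which 2 of the 3 values shown sit, already holds compound 3, the step is expected to be roughly a step that the limit leaves unreadable from compound 3 to compound 4. Compound 4 is accordingly estimated at 50000 nM, most likely again reported only as a limit.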

Compound 4, half-maximal inhibitory concentration: > 20000 nM
Compound 4 ended at the assay's limit; the forecaster's own chance of this, stated with the estimate: 90%; the middle value does not contradict the limit.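

Compound 3 and compound 4 both end at a limit in this assay, not at a number, so the step between them cannot be read: the limit of > 20000 nM in this assay, at which 3 of the 4 values shown sit.

The compounds shown leave open whether furan-3-yl in place of ethynyl changes inhibition on the core of compound 3 as sharply as it does on the core of compound 1.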